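Pyridin-2-yl to 2-chlorophenyl: notes toward compound 4

This account rests on a few compounds, and the source may have more. Where it says the series, first, only, none or still open, it means among the compounds named here.

Values measured so far in a functional assay on HCT-15 cells (Homo sapiens) for cytotoxicity, in the presence of a further agent that is not named here; a lower number here means a stronger inhibitor, a higher number a weaker inhibitor:

Compound 1 `Clc1ccc(-c2cc(-c3cccnc3)nc(-c3ccsc3)c2)o1` gives > 50000 nM, a limit of the assay.
Compound 2 `Cc1cccc(-c2cc(-c3ccc(Cl)o3)cc(-c3ccsc3)n2)c1` gives 21700 nM.
Compound 3 `Clc1ccc(-c2cc(-c3ccsc3)nc(-c3ccccn3)c2)o1` gives > 50000 nM, a limit of the assay.

Among the measured compounds shown here, compound 3 therefore stands at the limit of this assay, as does compound 1; compound 2 is the only member of the trio with a real number. The step of an at least 2.3-fold higher number from compound 2 to compound 3 (0.36 log units; beyond the scatter) is readable only as a lower bound, and a step that the two limits leave unreadable from compound 1 to compound 3 cannot be read at all because of the limit of > 50000 nM in this assay, at which 2 of the 3 values shown sit.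

Compound 4 `Clc1ccc(-c2cc(-c3ccsc3)nc(-c3ccccc3Cl)c2)o1` is the next target. 2-chlorophenyl in place of pyridin-2-yl on an aromatic carbon

For the measured compounds named here, two measured steps bear on this exchange of a pyridyl for a substituted phenyl: an at least 2.3-fold lower number from compound 1 to compound 2 (0.36 log units; beyond the scatter) and, read in reverse, an at least 2.3-fold higher number from compound 2 to compound 3 (0.36 log units; beyond the scatter). Both say that a substituted phenyl at this position gives a lower number than a pyridyl, and both are at least modest, though their full size is hidden because of the limit of > 50000 nM in this assay, at which 2 of the 3 values shown sit. A 2-chlorophenyl in place of pyridin-2-yl is expected to follow the same direction in this assay, bringing compound 4 below the limit and into the region of compound 2. The step of an at least 2.0-fold lower number from compound 3 to compound 4 (0.30 log units; that floor lies within the scatter) is accordingly the expected outcome. Compound 4 is estimated at 25000 nM, within 8000 nM to 60000 nM.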

Compound 4, half-maximal inhibitory concentration: 4570 nM
For compound 4 the middle estimate is 5.5-fold (0.74 log units) above the measured one; the measured number lies below the stated range.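

At the aromatic carbon next to the ring nitrogen, 2-chlorophenyl gives the first clear separation from the pyridyl compounds in this assay, with an at least 10-fold lower number from compound 3 to compound 4 (1.03 log units; beyond the scatter) and an at least 10-fold lower number from compound 1 to compound 4 (1.03 log units; beyond the scatter). Both steps are floors, and their full size stays hidden because of the limit: the limit of > 50000 nM in this assay, at which 2 of the 4 values shown sit. The substituted phenyls also differ from one another, with a 4.7-fold lower number from compound 2 to compound 4 (0.68 log units; beyond the scatter), so at this position the result depends on which substituted phenyl is present and not only on the exchange of a pyridyl for a phenyl ring.

Going by these compounds, that last step changes both the substituent and where it sits on the phenyl ring, and how phenyl without a substituent, 2-methylphenyl or 3-chlorophenyl would read here remains open, so the role of the chlorine cannot yet be separated from that of its place. Also open is how the series would respond to an amine or a carboxylic acid on this ring, or to any exchange of the 5-chlorofuran-2-yl or thiophen-3-yl groups, which stay the same across all the compounds shown.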